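A few compounds are considered here, and "the series" means these few. Any claim that something is new, unique, unknown or untested is made for them only; others in the source may bear on it.

Of the compounds shown here, three from this study have been tested in a functional assay for inhibition, with Homo sapiens as the target; on this read-out lower numbers stand for stronger inhibition and higher numbers for weaker inhibition. Compound 1 `CCCc1nc(C)c2c(C)nn(C)c(=O)n12` reaches only the limit of this assay, giving > 48000 nM. Compound 2 `CCCc1nc(C)c2c(C)nn(CCC)c(=O)n12` likewise reaches only the limit, with > 48000 nM in this assay . Compound 3 `C=CCSc1nncc2cnc(CCC)n12` also gives only a limit, > 48000 nM. The difference between the core of compound 3 and the core of compound 2 is not broken down here.

Compound 1 and compound 2 differ in one place: hydrogen in place of ethyl on a saturated chain carbon bound to an aromatic nitrogen. The step that the two limits leave unreadable from compound 2 to compound 1 cannot be sized, since both values are limits; all three values shown sit at the limit of > 48000 nM in this assay, at which 3 of the 3 values shown sit.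

Compound 4 `C=CCSc1nncc2cnc(C)n12` has not yet been measured. It differs from compound 3 by hydrogen in place of ethyl on a saturated chain carbon bound to an aromatic carbon. This is the same kind of change as that from compound 2 to compound 1, though there the saturated chain carbon is bound to an aromatic nitrogen and here to an aromatic carbon. In this assay compound 4 is expected to make a step that the limit leaves unreadable from compound 3 to compound 4, which is no more readable than the earlier one. That expectation rests on compound 3, whose value is only a limit, > 48000 nM. It also rests on the earlier pair, where the same kind of change left compound 2 and compound 1 both at the limit of > 48000 nM in this assay, at which 3 of the 3 values shown sit. Compound 4 is therefore estimated at 60000 nM, with an expected range from 20000 nM to 200000 nM, and the assay would most likely again report only a limit.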

Compound 4, half-maximal inhibitory concentration: 61000 nM
Compound 4: the middle estimate sits 1.0-fold (0.01 log units) below what was measured; measured number inside the range.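

In this assay compound 3 gives only a limit, > 48000 nM, so its difference from compound 4 cannot be sized and no new step can be read. The compounds shown leave open how far apart they truly lie and whether changing the chain or the core shifts this read-out at all, as most values remain at one limit: the limit of > 48000 nM in this assay, at which 3 of the 4 values shown sit.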